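Dropping One Fluorine from a Well-Tolerated Oxalamide

This account rests on a few compounds, and the source may have more. Where it says the series, first, only, none or still open, it means among the compounds named here.

Measured compounds:
- compound 1, `Cc1nc(C(NC(=O)C(=O)Nc2ccc(F)c(F)c2)C2CCCCN2)sc1CO`: > 87000 nM
- compound 2, `Cc1nc(C(NC(=O)C(=O)Nc2ccc(Cl)cc2)C2CCNCC2)sc1CCO`: 85400 nM
- compound 3, `Cc1nc(C(NC(=O)C(=O)Nc2ccc(F)c(F)c2)C2CCCCN2)sc1CCO`: > 78200 nM

Of the compounds shown here, three sharing one core have been tested in an ADME assay on TZM-b1 cells (Homo sapiens) for cytotoxicity, read by XTT assay, with a stated time of 3 days; a higher number here means that more compound is tolerated, a lower number that less compound is tolerated. For compound 1 the result is a limit of the assay rather than a number: > 87000 nM. For compound 3 the result is also a limit, > 78200 nM. Compound 2 gives a number, 85400 nM. Going by the values given here, the single change from compound 1 to compound 3, hydroxymethyl in place of hydroxy on a saturated chain carbon bound to an aromatic carbon, gives a step that the two limits leave unreadable from compound 1 to compound 3, so nothing about its size can be read.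

Compound 4, `Cc1nc(C(NC(=O)C(=O)Nc2ccc(F)cc2)C2CCCCN2)sc1CO`, is not yet measured. It differs from compound 1 by hydrogen in place of fluoro on an aromatic carbon, turning the 3,4-difluorophenyl group into a 4-fluorophenyl group. Among the compounds with values here, no measured step alters this part of the molecule, so there is no direct guide. What is available is that every value shown, the limit of > 78200 nM in this assay, at which 1 of the 3 values shown sits, and the limit of > 87000 nM in this assay, at which 1 of the 3 values shown sits, among them, lies at or near the top of what this assay can report.

Compound 4 is therefore expected to stay in that region, with an expected step that the limit leaves unreadable from compound 1 to compound 4, which is no more than scatter. The estimate for compound 4 is 90000 nM, in the range 45000 nM to 180000 nM, and a limit rather than a number is the likelier outcome.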

Compound 4, half-maximal cytotoxic concentration: > 90000 nM
Compound 4 was reported as a limit; the forecaster's own chance of this, stated with the estimate: 65%; the middle value lies on the limit itself.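

Compound 1 and compound 4 are both reported as limits rather than numbers in this assay, and the step between them cannot be read. The compounds shown leave open whether hydrogen in place of fluoro on this aromatic carbon changes how much compound is tolerated, and where the true values of compound 1 and compound 4 lie.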